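The source may report more compounds than this note shows. Statements on the series, on what has been measured and on what is new or still open speak of the compounds shown alone.

Compounds measured in an assay on SH-EP1 cells for displacement of a labelled ligand from Neuronal acetylcholine receptor; alpha4/beta2 (Homo sapiens), read by scintillation counting; on this read-out lower numbers stand for stronger inhibition and higher numbers for weaker inhibition:
- compound 1 `O=C([C@@H]1C[C@@H]1F)N1CC2CC(C1)N2`: 1.7 nM
- compound 2 `O=C([C@H]1C[C@@H]1F)N1CC2CC(C1)N2`: 5.4 nM

Compound 2 gives the highest of the two numbers in this assay; its nearest neighbour is compound 1, and the step is a 3.2-fold higher number from compound 1 to compound 2 (0.50 log units; beyond the scatter), a modest change that is nevertheless beyond the scatter. That step is tied to a single stereocentre on the cyclopropane, see (the fact that one of compounds 1 and 2 is drawn with a defined configuration and the other without, at the place where they differ).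

Compound 3 `O=C([C@@H]1C[C@H]1F)N1CC2CC(C1)N2` has not been measured. It differs from compound 2 only in configuration: the two compounds have the same atoms and bonds; at least one stereo element is drawn with a configuration in one of them and without one in the other: 2 of 4 stereo elements differ; a stereocentre at a saturated ring carbon is drawn R in compound 2 and S in compound 3; a stereocentre at a saturated ring carbon is drawn S in compound 2 and R in compound 3. Both cyclopropane centres are inverted at once, so compound 3 carries the mirror-image cyclopropane relative to compound 2. Among the compounds with values here, the only step that bears on this is the one between compound 1 and compound 2; it shows that a single inversion moves the number modestly. Within the data shown here, a double inversion has no direct precedent here, so the direction is uncertain. Compound 3 is expected to land near the two measured values, with the step from compound 2 estimated as a 1.5-fold lower number from compound 2 to compound 3 (0.19 log units; within the scatter). The estimate for compound 3 in this assay is 3.5 nM, within a range of 1 nM to 14 nM.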

Compound 3, inhibition constant: 1 nM
Compound 3: the middle estimate sits 3.5-fold (0.54 log units) above what was measured; the measured number falls inside the stated range.
By their numbers in this assay, from the lowest: compounds 3 and 1 (each within the scatter of the next); then compound 2.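

In this assay, inverting both cyclopropane centres of compound 2 gives a 5.4-fold lower number from compound 2 to compound 3 (0.73 log units; beyond the scatter), and with atoms and bonds unchanged this step rests on configuration alone: the fact that one of compounds 2 and 3 is drawn with a defined configuration and the other without, at the place where they differ.
Within the data shown here, the single-centre change gives a 1.7-fold lower number from compound 1 to compound 3 (0.23 log units; within the scatter), so this inversion, unlike the one separating compound 1 from compound 2, leaves the number within the scatter and compounds 1 and 3 cannot be ordered.
Among these three compounds the sensitivity to configuration at the cyclopropane therefore depends on which centre changes and from which starting arrangement, with only compound 2 standing apart from the other two.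

As far as these compounds go, the remaining configuration of the fluorocyclopropane amide is still open.
So is whether the same dependence on configuration holds with a chlorine atom or a methyl group in place of the fluorine.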